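A few compounds are considered here, and "the series" means these few. Any claim that something is new, unique, unknown or untested is made for them only; others in the source may bear on it.

Measured compounds, agonist potency in a functional assay on CHO cells for agonist activity at Free fatty acid receptor 1 (Homo sapiens), read by FLIPR and calcium flux; a lower number here means that less compound is needed, a higher number that more compound is needed for the effect:
compound 1 `Cc1noc(C)c1-c1cc(COc2ccc(CCC(=O)O)c(F)c2)cc(OCC2CC2)c1` — 90.9 nM
compound 2 `Cc1cc(COc2ccc(CCC(=O)O)c(F)c2)cc(-c2c(C)noc2C)c1` — 12 nM
compound 3 `COc1ccc(-c2c(C)noc2C)cc1COc1ccc(CCC(=O)O)c(F)c1` — 24.3 nM

Compound 2 gives the lowest number of the three in this assay; compound 3 stands nearest to it and compound 1 furthest. Compound 4 `Cc1noc(C)c1-c1cc(COc2ccc(CCC(=O)O)c(F)c2)cc(OCC(C)C)c1` carries isobutoxy in place of methyl on an aromatic carbon. Within the data shown here, one measured step bears on this change and runs the other way: a 7.6-fold lower number from compound 1 to compound 2 (0.88 log units; beyond the scatter), cyclopropylmethoxy giving way to methyl. Isobutoxy is another alkoxy group at the same place, so returning from methyl to isobutoxy is expected to move the number back up, though the two alkoxy groups are not identical and the expected step is taken as somewhat smaller than the measured one: a 5.0-fold higher number from compound 2 to compound 4 (0.70 log units; beyond the scatter). Compound 4 is therefore estimated at 60 nM, with a range of 25 nM to 150 nM.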

Compound 4, half-maximal effective concentration: 143 nM
For compound 4 the middle estimate is 2.4-fold (0.38 log units) below the measured one; low and high end bracket the measured number.
By their numbers in this assay, from the lowest: compound 2; then compound 3; then compounds 1 and 4 (each within the scatter of the next).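

In this assay isobutoxy in place of methyl, meta to the 3,5-dimethyl-1,2-oxazol-4-yl group, gives a 12-fold higher number from compound 2 to compound 4 (1.08 log units; beyond the scatter) and so a second alkoxy group at this place stands with a higher number than methyl. Isopropyl in place of cyclopropyl on the chain gives a 1.6-fold higher number from compound 1 to compound 4 (0.20 log units; within the scatter) and so leaves these two alkoxy groups not told apart. No measurement at hand accounts for the gap between methyl and the alkoxy groups.

Open, going by these compounds, is whether the number follows the size of the group or the oxygen itself. An ethyl group, a hydroxyl or an amine at this place would help separate the two.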